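The source may report more compounds than this note shows. Statements on the series, on what has been measured and on what is new or still open speak of the compounds shown alone.

Measured so far in a functional assay on DU-145 cells (Homo sapiens) for inhibition, read by trypan blue exclusion, with a stated time of 96 h (a lower number here means a stronger inhibitor of growth, a higher number a weaker inhibitor of growth), and the values obtained:
- compound 1 `O=C(/C(=C\c1ccc(O)cc1)SCc1ccc(Cl)cc1)c1ccc(Br)cc1` gives 10000 nM
- compound 2 `O=C(/C(=C\c1ccc([N+](=O)[O-])c(O)c1)S(=O)(=O)c1ccc(Br)cc1)c1c(F)c(F)c(F)c(F)c1F` gives 1000 nM

Of the two, compound 2 has the lower number at 1000 nM and is the stronger inhibitor of growth, with a gap to compound 1 beyond the usual scatter. The two compounds differ in several places at once, so their values isolate no single change.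

Compound 3 `O=C(/C(=C\c1ccc([N+](=O)[O-])c(O)c1)Sc1ccc(Br)cc1)c1c(F)c(F)c(F)c(F)c1F` has not yet been measured. It carries (4-bromophenyl)sulfanyl in place of (4-bromophenyl)sulfonyl on a double-bonded chain carbon bound to a carbonyl carbon and a double-bonded chain carbon.

Among the measured compounds shown here, no measured pair covers this change, so the expectation is loose. Compound 1, which also lacks a sulfonyl, gives 10000 nM and offers the only hint, a weak one, towards a higher number. A modest weakening in this assay is expected, although a step within the scatter remains possible. The estimated change is a 2.5-fold higher number from compound 2 to compound 3 (0.40 log units; beyond the scatter) and is only an expectation. The expected value for compound 3 is 2500 nM (estimated range 700 nM to 9000 nM).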

Compound 3, concentration for 50% growth inhibition: 1000 nM
Beside the measured number, compound 3's estimate is 2.5-fold (0.40 log units) above it; measured number inside the range.
By their numbers in this assay, from the lowest: compounds 2 and 3 (each within the scatter of the next); then compound 1.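

In this assay, among the compounds shown here, the step to (4-bromophenyl)sulfanyl in place of (4-bromophenyl)sulfonyl is the first comparison that isolates a single place, and it reads no change at the digits printed from compound 2 to compound 3 (within the scatter). On the core of compound 2, the two sulfur-linked groups at this double-bonded chain carbon, bound to a carbonyl carbon and a double-bonded chain carbon, therefore cannot be told apart by growth inhibition, although the sulfonyl oxygen atoms are lost in the step. Nothing available explains this lack of separation between the two groups.

Going by these compounds, compound 1 gives 10000 nM but differs from compound 3 in several places, so no part of its gap can be assigned to any one group, and it remains open whether the same step would read alike on the core of compound 1. Also open, on these data alone, is how this position would respond to a sulfinyl, an amine or an ether oxygen as the link to the 4-bromophenyl ring, or to a group other than bromine on that ring.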